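From 4-fluorophenyl to 3-methoxyphenyl in the series

The compounds below may be only part of what the source reports. "The series", "measured", "known", "first", "only" and "open" are said of these compounds alone.

In a functional assay on PC-9 cells (Homo sapiens) for antiproliferative activity, read by MTT assay, with a stated time of 72 h (a higher number here means a weaker inhibitor, a lower number a stronger inhibitor), compound 1 `COc1ccc(Nc2cc(NC(=O)c3ccccc3)ncn2)cc1` gives 660 nM and compound 2 `COc1ccc(OC)c(Nc2cc(Nc3ccc(F)cc3)ncn2)c1` gives 640 nM as values within the scatter of each other. Compound 3 `COc1cccc(Nc2cc(Nc3cccc(Cl)c3)ncn2)c1` gives 1660 nM and stands beyond the scatter from compound 2, on the weaker side. Compound 4 `COc1cccc(Nc2cc(Nc3cc(OC)ccc3OC)ncn2)c1` differs from compound 2 by 3-methoxyphenyl in place of 4-fluorophenyl on a nitrogen on an aromatic ring with 3-methoxyphenyl in place of 4-fluorophenyl on a nitrogen on an aromatic ring. For the measured compounds named here, no measured pair isolates this change. The 3-methoxyphenyl group also occurs in compound 3 at 1660 nM and this points to some loss. A small estimated step of a 1.5-fold higher number from compound 2 to compound 4 (0.17 log units; within the scatter) is expected in this assay toward a higher number. Compound 4 is estimated at 950 nM with a range of 350 nM to 2600 nM expected.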

Compound 4, half-maximal inhibitory concentration: 450 nM
Beside the measured number, compound 4's estimate is 2.1-fold (0.32 log units) above it; low and high end bracket the measured number.
By their numbers in this assay, from the lowest: compounds 4, 2 and 1 (each within the scatter of the next); then compound 3.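

In this assay, 3-methoxyphenyl in place of 4-fluorophenyl on a nitrogen on an aromatic ring gives a 1.4-fold lower number from compound 2 to compound 4 (0.15 log units; within the scatter), so this position accepts either group with no loss that can be read. The 3-methoxyphenyl group that compound 4 shares with compound 3 at 1660 nM is thus not tied to a higher number on its own.

Open, on these data alone, is whether an amine or a carboxylic acid on the phenyl ring at this nitrogen would give a step beyond the scatter. No measurement shown accounts for the closeness of compound 2 and compound 4.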